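This account rests on a few compounds, and the source may have more. Where it says the series, first, only, none or still open, it means among the compounds named here.

In a functional assay on A549 cells (Homo sapiens) for cytotoxicity, read by MTT assay, with a stated time of 72 h (a higher number here means a weaker inhibitor, a lower number a stronger inhibitor), compound 1 (`CN(C)CCn1cnnc1-c1cc(Oc2ccc(NC(=O)N/N=C/c3ccccc3O[N+](=O)[O-])cc2F)ccn1`) gives 1200 nM and compound 2 (`CN(C)CCn1cnnc1-c1cc(Oc2ccc(NC(=O)N/N=C/c3ccccc3)cc2F)ccn1`) gives 1860 nM. Within the data shown here, these are the only two numbers in hand, and they lie within the scatter of each other, so compound 2 cannot be ranked apart from compound 1. Compound 3 (`CN(C)CCn1cnnc1-c1cc(Oc2ccc(NC(=O)N/N=C/c3cccc(Cl)c3Cl)cc2F)ccn1`) carries 2,3-dichlorophenyl in place of phenyl on a carbon with a double bond to nitrogen. Among the measured compounds shown here, the only measured step that bears on this change, a 1.6-fold higher number from compound 1 to compound 2 (0.19 log units; within the scatter), put hydrogen in place of nitrooxy on an aromatic carbon and stayed within the scatter. It is a single, small step and does not involve chlorine, so no shift beyond the scatter is expected in this assay. The expected change is a 1.7-fold lower number from compound 2 to compound 3 (0.23 log units; within the scatter). Compound 3 is estimated at 1100 nM, with an expected range from 350 nM to 3500 nM.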

Compound 3, half-maximal inhibitory concentration: 1090 nM
Compound 3: the middle estimate sits 1.0-fold (0.00 log units) above what was measured; low and high end bracket the measured number.
By their numbers in this assay, from the lowest: compounds 3, 1 and 2 (each within the scatter of the next).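

In this assay, the step of a 1.7-fold lower number from compound 2 to compound 3 (0.23 log units; within the scatter) shows that the place on the carbon with a double bond to nitrogen accepts 2,3-dichlorophenyl in place of phenyl with no shift that can be told from the scatter. The step of a 1.1-fold lower number from compound 1 to compound 3 (0.04 log units; within the scatter) adds that 2,3-dichlorophenyl and 2-(nitrooxy)phenyl cannot be told apart there either, so this place has now borne three different groups with numbers that stay within the scatter of one another. Nothing measured here bears on why these numbers stay together.

The compounds shown leave open whether a group of another kind on the phenyl, such as a carboxylic acid or a nitrile, would move the number beyond the scatter. They also leave open whether a single chlorine would behave as the two chlorines do.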